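Moving the thiazole attachment point in an acid ceramidase series

A few compounds are considered here, and "the series" means these few. Any claim that something is new, unique, unknown or untested is made for them only; others in the source may bear on it.

Compound 3 `O=C(NCCCCc1ccccc1)n1cc(-c2nccs2)oc1=O` gives 59 nM in an assay on isolated protein for inhibition of acid ceramidase (Homo sapiens), read by LC-MS, with a stated time of 1 h (a higher number here means a weaker inhibitor, a lower number a stronger inhibitor), the lowest of the three numbers measured. Compound 1 `O=C(NCCCCc1ccccc1)n1cc(-c2ccc(F)cc2)oc1=O` gives 185 nM and compound 2 `COc1ccc(-c2cn(C(=O)NCCCCc3ccccc3)c(=O)o2)cc1` gives 400 nM; the steps of a 3.1-fold lower number from compound 1 to compound 3 (0.50 log units; beyond the scatter) and a 6.8-fold lower number from compound 2 to compound 3 (0.83 log units; beyond the scatter) both favour compound 3. Compound 4 `O=C(NCCCCc1ccccc1)n1cc(-c2cscn2)oc1=O` differs from compound 3 by 1,3-thiazol-4-yl in place of 1,3-thiazol-2-yl on an aromatic carbon. For the measured compounds named here, no measured step tests this kind of change: the steps from compound 1 and compound 2 to compound 3 swap a fluorophenyl or methoxyphenyl group for the thiazole, whereas here the same atoms are kept and only joined differently. The change is therefore expected to be small, with a 1.7-fold higher number from compound 3 to compound 4 (0.23 log units; within the scatter). Compound 4 is estimated at 100 nM, within a range from 35 nM to 300 nM.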

Compound 4, half-maximal inhibitory concentration: 44 nM
Compound 4: middle estimate off by 2.3-fold (0.36 log units), on the high side, within the range that was stated.
By their numbers in this assay, from the lowest: compounds 4 and 3 (each within the scatter of the next); then compound 1; then compound 2.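

Swapping 1,3-thiazol-2-yl for 1,3-thiazol-4-yl gives a 1.3-fold lower number from compound 3 to compound 4 (0.13 log units; within the scatter) and so shows no clear effect of how the thiazole is joined at this position. The gain over the substituted phenyl groups holds for this second attachment too, with a 4.2-fold lower number from compound 1 to compound 4 (0.62 log units; beyond the scatter) and a 9.1-fold lower number from compound 2 to compound 4 (0.96 log units; beyond the scatter) in the same direction as the steps to compound 3. No measurement on hand explains these numbers.

Still open, going by these compounds, is whether a pyridine or an oxazole in this place would give numbers as low as those of compound 3 and compound 4. Also open, on these data alone, is whether a shorter chain in place of the phenylbutyl group would leave the two thiazoles this close.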